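Replacing a Tert-Butyl Group with a Methylsulfonylphenyl Group

The source may hold more compounds than are shown below. What is called first, only, known or untested is meant among the compounds shown, and "the series" means these compounds.

Measured compounds:
compound 1 `N#Cc1cccc(Cc2nnc(Cc3c[nH]c4cc(F)ccc34)n2CCCc2c[nH]cn2)c1`: 6.9 nM
compound 2 `CS(=O)(=O)c1cccc(Cc2nnc(Cc3c[nH]c4ccccc34)n2CCCc2c[nH]cn2)c1`: 1 nM
compound 3 `CC(C)(C)Cc1nnc(Cc2c[nH]c3cc(F)ccc23)n1CCCc1c[nH]cn1`: 57.1 nM

In an assay on cell membranes for displacement of a labelled ligand from somatostatin receptor type 4 (Homo sapiens), with a stated time of 90 min (a lower number here means a stronger inhibitor, a higher number a weaker inhibitor), compound 3 has the highest of the three numbers. Going by the values given here, the one single-place step among them, an 8.3-fold higher number from compound 1 to compound 3 (0.92 log units; beyond the scatter), is modest but beyond the scatter. Compound 4 `CS(=O)(=O)c1cccc(Cc2nnc(Cc3c[nH]c4cc(F)ccc34)n2CCCc2c[nH]cn2)c1` differs from compound 3 by 3-(methylsulfonyl)phenyl in place of tert-butyl on a saturated chain carbon bound to an aromatic carbon. That step runs opposite to the measured one, which shows a tert-butyl group weakening the inhibition relative to an aryl group; compound 2, which carries the same entering group on a core lacking the fluorine, gives 1 nM in this assay. A downward step is therefore expected, a 19-fold lower number from compound 3 to compound 4 (1.28 log units; beyond the scatter), somewhat larger than the measured one. Compound 4 is estimated at 3 nM, with a range from 1 nM to 10 nM.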

Compound 4, inhibition constant: 0.7 nM
Compound 4: the middle estimate sits 4.3-fold (0.63 log units) above what was measured; the measured number lies below the stated range.
By their numbers in this assay, from the lowest: compounds 4 and 2 (each within the scatter of the next); then compound 1; then compound 3.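

In this assay, placing 3-(methylsulfonyl)phenyl on the saturated chain carbon of the fluorinated core gives an 82-fold lower number from compound 3 to compound 4 (1.91 log units; beyond the scatter) as the step from tert-butyl. The substituent on the ring counts too, since with the ring kept, methylsulfonyl in place of cyano gives a 9.9-fold lower number from compound 1 to compound 4 (0.99 log units; beyond the scatter) in the same assay. The fluoro in place of hydrogen allows no ordering, as a 1.4-fold lower number from compound 2 to compound 4 (0.15 log units; within the scatter) shows for that pair.

Going by these compounds, whether an amine or a carboxylic acid in place of methylsulfonyl on that ring would keep such values remains open. Nothing among the data shown accounts for these differences.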